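Cytotoxicity of an acylthiocarbamate series on MT4 cells

A few compounds are considered here, and "the series" means these few. Any claim that something is new, unique, unknown or untested is made for them only; others in the source may bear on it.

Measured so far:
- compound 1, `Cc1ccccc1C(=O)N(C(=S)OCCN1C(=O)c2ccccc2C1=O)c1ccc(Cl)cc1`: 21000 nM
- compound 2, `Cc1ccc(N(C(=O)c2ccccc2C)C(=S)OCCN2C(=O)c3ccccc3C2=O)cc1`: > 100000 nM
- compound 3, `Cc1cc(C(=O)N(C(=S)OCCN2C(=O)c3ccccc3C2=O)c2ccc(Cl)cc2)c(C)o1`: 40000 nM

In an ADME assay on MT4 cells (Homo sapiens) for cytotoxicity, read by MTT assay (on this read-out higher numbers stand for lower toxicity in this test and lower numbers for higher toxicity in this test), compound 2 reaches only a limit of the assay, > 100000 nM, and so has no exact number; it sits at the limit of > 100000 nM in this assay, at which 1 of the 3 values shown sits. Compound 4, `Cc1ccc(N(C(=O)c2cc(F)cc(F)c2)C(=S)OCCN2C(=O)c3ccccc3C2=O)cc1`, is not yet measured. It differs from compound 2 by 3,5-difluorophenyl in place of 2-methylphenyl on a carbonyl carbon. Among the measured compounds shown here, the one measured step at this position is a 1.9-fold higher number from compound 1 to compound 3 (0.28 log units; within the scatter), which lies within the scatter. The other step, an at least 4.7-fold higher number from compound 1 to compound 2 (0.67 log units; beyond the scatter), is at a different place and does not bear directly on this change. Accordingly no step beyond the scatter is expected for this change, so a number no higher from compound 2 to compound 4 (the limit leaves the size open) is the estimated step. Compound 4 is expected to give about 100000 nM, within 40000 nM to 250000 nM, and may again reach only a limit.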

Compound 4, half-maximal cytotoxic concentration: 54000 nM
Compound 4: middle estimate off by 1.9-fold (0.27 log units), on the high side, and the stated range covers the measured number.
By their numbers in this assay, from the lowest: compounds 1, 3 and 4 (each within the scatter of the next, the first and the last beyond it). At a limit, above all of these: compound 2.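

In this assay the 3,5-difluorophenyl compound gives an exact number, compound 4 (54000 nM), so this carbonyl position can be read with the methyl group on the shared core. Compound 2 stands at a limit of the assay (> 100000 nM). From the compounds shown here alone, the change reads as an at least 1.8-fold lower number from compound 2 to compound 4 (0.26 log units; that floor lies within the scatter) and its true size stays open because one end of the step is a limit: the limit of > 100000 nM in this assay, at which 1 of the 4 values shown sits.

Whether the lower number reaches beyond the scatter remains unresolved. Also open, going by these compounds, is what an amine or a carboxylic acid on the aromatic ring at this carbonyl carbon would give.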